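Dropping the terminal vinyl from a polyacetylenic alcohol

A few compounds are considered here, and "the series" means these few. Any claim that something is new, unique, unknown or untested is made for them only; others in the source may bear on it.

Compound 2 `C=CCCCCCCCC#CC#CCO` gives 3.94 ug/mL in a functional assay on SK-MEL-2 cells (Homo sapiens) for cytotoxicity (on this read-out higher numbers stand for an effect only at larger amounts of compound and lower numbers for an effect already at smaller amounts), the lowest of the two numbers recorded so far; its nearest neighbour is compound 1 `C=CCCCCCC#CC#CCO`, which in this assay gives 9.56 ug/mL. Within the data shown here, the one measured step, a 2.4-fold lower number from compound 1 to compound 2 (0.38 log units; beyond the scatter), shows that a longer unsaturated end of the chain went with the lower number. Compound 3 `CCCCCCCC#CC#CCO` carries the change (hydrogen in place of vinyl on a saturated chain carbon, seven bonds along the chain from a triple-bonded carbon), which shortens the chain of compound 2 back to the length of compound 1 while leaving it fully saturated at that end. Since the step from compound 1 to compound 2 ran toward lower numbers with the longer chain, the reverse shortening is expected to raise the number for compound 3 by about a 1.9-fold higher number from compound 2 to compound 3 (0.28 log units; within the scatter). Compound 3 is therefore estimated at 7.5 ug/mL in this assay, with a range of 3.5 ug/mL to 16 ug/mL.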

Compound 3, concentration for half-maximal effect: 4.45 ug/mL
Beside the measured number, compound 3's estimate is 1.7-fold (0.23 log units) above it, within the range that was stated.
By their numbers in this assay, from the lowest: compounds 2 and 3 (each within the scatter of the next); then compound 1.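

In this assay, hydrogen in place of vinyl on a saturated chain carbon, seven bonds along the chain from a triple-bonded carbon, gives a 1.1-fold higher number from compound 2 to compound 3 (0.05 log units; within the scatter), so at this place the terminal double bond of compound 2 can go without a change beyond the usual scatter. Ethyl in place of vinyl, five bonds along the chain from a triple-bonded carbon, gives a 2.1-fold lower number from compound 1 to compound 3 (0.33 log units; beyond the scatter), which shows that at one chain length the saturated end goes with the lower number, so the step seen earlier need not be read as a matter of chain length alone. No measurement here explains these numbers.

The compounds shown leave open whether a longer saturated chain would carry the number further in the same direction. They also leave open how a hydroxyl group or a phenyl ring at this end of the chain would read.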